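Swapping a methyl for a trifluoromethylphenyl on the sulfonyl arene

The compounds below may be only part of what the source reports. "The series", "measured", "known", "first", "only" and "open" are said of these compounds alone.

Compound 1, `Cc1ccc(S(=O)(=O)N2CCC(N3CCC(C)CC3)CC2)cc1C`: 24 nM in a functional assay on DLD-1 cells (Homo sapiens) for antiproliferative activity, read by CellTiter-Glo, with a stated time of 72 h; on this read-out lower numbers stand for stronger inhibition and higher numbers for weaker inhibition.
Compound 2, `Cc1cccc(S(=O)(=O)N2CCC(N3CCC(C)CC3)CC2)c1`: 25 nM.
Compound 3, `CC1CCN(C2CCN(S(=O)(=O)c3nccn3C)CC2)CC1`: only the assay limit is reported, > 5000 nM.

Compound 2 gives the higher of the two numbers shown, yet its step from compound 1 is a 1.0-fold higher number from compound 1 to compound 2 (0.02 log units; within the scatter). Compound 4, `CC1CCN(C2CCN(S(=O)(=O)c3cccc(-c4ccccc4C(F)(F)F)c3)CC2)CC1`, differs from compound 2 by 2-(trifluoromethyl)phenyl in place of methyl on an aromatic carbon. Within the data shown here, no measured step makes this kind of change. The step of a 1.0-fold higher number from compound 1 to compound 2 (0.02 log units; within the scatter) shows that a methyl on that ring makes no difference beyond the scatter, while an at least 200-fold higher number from compound 2 to compound 3 (2.30 log units; beyond the scatter) shows that exchanging the whole arene for a methylimidazolyl costs a great deal. A small step is therefore expected in this assay, probably within the scatter. Compound 4 is estimated at 40 nM, with a range from 10 nM to 160 nM. The expected step is thus a 1.6-fold higher number from compound 2 to compound 4 (0.20 log units; within the scatter).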

Compound 4, half-maximal inhibitory concentration: 10 nM
Estimate against measurement, compound 4: 4.0-fold (0.60 log units) above; measured number inside the range.
By their numbers in this assay, from the lowest: compound 4; then compounds 1 and 2 (each within the scatter of the next). At a limit, above all of these: compound 3.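

In this assay, the aromatic carbon that carried a methyl in compound 2 accepts a much larger 2-(trifluoromethyl)phenyl group, and activity is not lost: the change gives a 2.5-fold lower number from compound 2 to compound 4 (0.40 log units; beyond the scatter). This is the first change shown at this carbon, and it shows that the position can hold a second aromatic ring and that the number moves beyond the scatter. Nothing measured here explains this gain.

As far as these compounds go, it remains open whether the trifluoromethyl group contributes to the gain, or whether a plain phenyl would do the same. From the compounds shown here alone, how an amine or a carboxylic acid at this carbon would fare also remains open.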